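Swapping chloro for fluoro on a benzamide sulfonamide

This account rests on a few compounds, and the source may have more. Where it says the series, first, only, none or still open, it means among the compounds named here.

Measured so far:
Compound 1, `Cc1ccc(S(=O)(=O)NCc2ccc(CNC(=O)c3ccc(Cl)cc3)cc2)cc1`: 10 nM
Compound 2, `O=C(NCc1ccc(CNS(=O)(=O)c2ccccc2)cc1)c1ccncc1`: 10 nM

Of the compounds shown here, two have been tested in an assay on MDA-MB-231 cells for binding affinity to C-X-C chemokine receptor type 4 (Homo sapiens), read by immunofluorescence and microscopy, with stated times of 10 min and 30 min; on this read-out lower numbers stand for an effect already at smaller amounts and higher numbers for an effect only at larger amounts of compound. Compound 1 gives 10 nM in this assay. Compound 2 differs from compound 1 at several places; in this assay compound 2 gives 10 nM. On the digits shown, compound 1 stands level with compound 2, and the two values lie within the usual scatter of each other, so no order between them can be read from these numbers.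

Compound 3, `Cc1ccc(S(=O)(=O)NCc2ccc(CNC(=O)c3ccc(F)cc3)cc2)cc1`, has not yet been measured in this assay. It differs from compound 1 by a single change: fluoro in place of chloro on an aromatic carbon. The rest of the shared core stays the same. Going by the values given here, no step between measured compounds that share this single change is available, so there is nothing here to show how this exchange affects the result.

The expectation for compound 3 is therefore a step of about a 1.5-fold higher number from compound 1 to compound 3 (0.18 log units; within the scatter), not beyond the scatter, with a value estimated at 15 nM, in a range from 5 nM to 45 nM.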

Compound 3, effective concentration (reported as EC, without a stated level of effect): 1 nM
Compound 3: the middle estimate sits 15-fold (1.18 log units) above what was measured, outside the stated range (below it).
By their numbers in this assay, from the lowest: compound 3; then compounds 1 and 2 (each within the scatter of the next).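

In this assay, the exchange of 4-chlorophenyl for 4-fluorophenyl gives a 10-fold lower number from compound 1 to compound 3 (1.00 log units; beyond the scatter), a step beyond the scatter. Going by these compounds alone, this shows that the result responds to the identity of the single halogen atom on this aromatic carbon, para to a large group, even though the count of heavy atoms, hydrogen-bond donors and hydrogen-bond acceptors stays the same; the earlier compounds offered no pair differing in one place, so they could not show this. Nothing available explains why this exchange shifts the result.

The compounds shown leave open whether the trend continues across other groups at this position, since a bromo group, a methoxy group, an amine or plain hydrogen would each show whether the number keeps falling, rises again or hardly moves. They also leave open whether the same exchange gives a step of similar size on a different core, for example one without the methyl group on the sulfonyl-bearing ring, as a single pair cannot establish a pattern.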